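Swapping a bromophenyl for a benzyloxy group on two cores

This account rests on a few compounds, and the source may have more. Where it says the series, first, only, none or still open, it means among the compounds named here.

Compound 1 `CC1(c2ccccc2)CC(=O)C(C2CC(c3ccc(-c4ccc(Br)cc4)cc3)Cc3ccccc32)=C(O)O1` in a functional assay on HCT-15 cells (Homo sapiens) for inhibition, with a stated time of 72 h (on this read-out lower numbers stand for stronger inhibition and higher numbers for weaker inhibition), gives 1310 nM. Compound 2 `CC1(c2ccccc2)CC(=O)C(C2CC(c3ccc(OCc4ccc(C(F)(F)F)cc4)cc3)Cc3ccccc32)=C(O)O1` differs from it by (4-(trifluoromethyl)benzyl)oxy in place of 4-bromophenyl on an aromatic carbon. In this assay compound 2 reports only a limit, > 10000 nM. That change produced an at least 7.6-fold higher number from compound 1 to compound 2 (0.88 log units; beyond the scatter). Compound 3 `CCCC1(CCc2ccccc2)CC(=O)C(C2CC(c3ccc(-c4ccc(Br)cc4)cc3)Cc3ccccc32)=C(O)O1` has a different core; the difference between the two cores is not broken down here. In this assay compound 3 also reports only a limit, > 10000 nM. This matches (the limit of > 10000 nM in this assay, at which 2 of the 3 values shown sit). Compound 4 `CCCC1(CCc2ccccc2)CC(=O)C(C2CC(c3ccc(OCc4ccc(C(F)(F)F)cc4)cc3)Cc3ccccc32)=C(O)O1` carries (4-(trifluoromethyl)benzyl)oxy in place of 4-bromophenyl on an aromatic carbon, the same change on the other core. Because compound 1 showed an at least 7.6-fold higher number from compound 1 to compound 2 (0.88 log units; beyond the scatter) and compound 3 already sits at the limit, compound 4 is expected to stay at or beyond the limit, with an estimated step that the limit leaves unreadable from compound 3 to compound 4. Compound 4 is therefore estimated at 30000 nM in this assay, within 10000 nM to 100000 nM.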

Compound 4, half-maximal inhibitory concentration: > 10000 nM
Compound 4: a limit, no number; the forecaster's own chance of this, stated with the estimate: 95%; the middle value is on the limit's open side.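

No step can be read between compound 3 and compound 4, as each reports only a limit: the limit of > 10000 nM in this assay, at which 3 of the 4 values shown sit.

The compounds shown leave open what (4-(trifluoromethyl)benzyl)oxy in place of 4-bromophenyl does on the core of compound 3 in this assay.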